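A few compounds are considered here, and "the series" means these few. Any claim that something is new, unique, unknown or untested is made for them only; others in the source may bear on it.

Measured in an ADME assay on Vero 76 cells (Chlorocebus sabaeus) for cytotoxicity, read by microscopy; a higher number here means that more compound is tolerated, a lower number that less compound is tolerated:
- compound 1 `OC[C@@]12C[C@@H]1[C@@H](n1cnc3c(NCc4ccccc4)nc(Cl)nc31)[C@H](O)[C@@H]2O`: > 100000 nM
- compound 2 `O[C@@H]1[C@H](O)[C@@H]2C[C@@H]2[C@H]1n1cnc2c(NC(C3CCC3)C3CCC3)nc(Cl)nc21`: 16000 nM
- compound 3 `CC(C)[C@@H](Nc1nc(Cl)nc2c1ncn2[C@H]1[C@H](O)[C@H](O)[C@]2(CF)C[C@H]12)C1CC1`: 36000 nM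

Compound 1 stands at the limit of > 100000 nM in this assay, at which 1 of the 3 values shown sits, and this reading is a limit, not a number. Compound 4 `CC(C)(C)[C@H](Nc1nc(Cl)nc2c1ncn2[C@H]1[C@H](O)[C@H](O)[C@]2(CO)C[C@H]12)C1CC1` is not yet measured. It differs from compound 1 by 1-cyclopropyl-2,2-dimethylpropyl in place of benzyl on a nitrogen on an aromatic ring. For the measured compounds named here, no measured pair isolates this change. Compound 3, at 36000 nM, also lacks the benzyl, so a lower tolerated concentration is expected in this assay, with a step beyond the scatter. The expected step is an at least 2.2-fold lower number from compound 1 to compound 4 (0.34 log units; beyond the scatter). For compound 4 the estimate is 45000 nM, with an expected range of 18000 nM to 100000 nM.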

Compound 4, half-maximal cytotoxic concentration: > 100000 nM
Compound 4 was reported as a limit; the forecaster's own chance of this, stated with the estimate: 30%; at least 2.2-fold (0.34 log units) between middle value and limit.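

In this assay, compound 1 and compound 4 are both reported as limits, not numbers, so no step between them can be read: the limit of > 100000 nM in this assay, at which 2 of the 4 values shown sit.

The compounds shown leave open whether 1-cyclopropyl-2,2-dimethylpropyl in place of benzyl changes the tolerated concentration at all.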